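The compounds below may be only part of what the source reports. "The series", "measured", "known", "first", "only" and "open" are said of these compounds alone.

In a functional assay on K562 cells (Homo sapiens) for inhibition (on this read-out lower numbers stand for stronger inhibition and higher numbers for weaker inhibition), compound 1 `CCOC(=O)C1=C(Nc2ccccc2)S/C(=C\C2CCCCC2)C1=O` gives 5900 nM and compound 2 `CCOC(=O)C1=C(Nc2ccccc2)S/C(=C\c2cc3ncccc3[nH]2)C1=O` gives 6600 nM. Within the data shown here, these are the only two numbers so far. They lie within the scatter of each other, so compound 2 cannot be ranked against compound 1.

Compound 3 `CCOC(=O)C1=C(Nc2ccccc2)S/C(=C\c2ccc(F)c(C#N)c2)C1=O` differs from compound 2 by one change: a group of 9 heavy atoms (7 carbon, 1 nitrogen, 1 fluorine; one six-membered aromatic ring of carbon only) in place of a group of 9 heavy atoms (7 carbon, 2 nitrogen; one five-membered aromatic ring with 1 hetero atom, one six-membered aromatic ring with 1 hetero atom), on a double-bonded chain carbon bound to a double-bonded ring carbon. The 3-cyano-4-fluorophenyl group enters on a double-bonded chain carbon bound to a double-bonded ring carbon.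

Among the measured compounds shown here, the one measured step at this place is a 1.1-fold higher number from compound 1 to compound 2 (0.05 log units; within the scatter), and it stays within the scatter even though a non-aromatic ring gives way to aromatic rings. With that single step as the guide, no change beyond the scatter is expected in this assay. For the measured compounds named here, no measured compound yet carries a carbon-only aromatic ring here, so the range stays wide. The expected step is a 1.3-fold lower number from compound 2 to compound 3 (0.12 log units; within the scatter). For compound 3 the estimated value is 5000 nM, with an expected range of 1800 nM to 15000 nM.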

Compound 3, half-maximal inhibitory concentration: 1600 nM
Compound 3: the middle estimate sits 3.1-fold (0.49 log units) above what was measured, and the stated range ends above it.
By their numbers in this assay, from the lowest: compound 3; then compounds 1 and 2 (each within the scatter of the next).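

In this assay the group on the double-bonded chain carbon bound to a double-bonded ring carbon now shows an effect that compound 1 and compound 2 could not show: 3-cyano-4-fluorophenyl gives a 4.1-fold lower number from compound 2 to compound 3 (0.62 log units; beyond the scatter) against the group with two aromatic rings, and a 3.7-fold lower number from compound 1 to compound 3 (0.57 log units; beyond the scatter) against cyclohexyl. Both steps lie beyond the scatter, so compound 3 stands lowest of the three, and the step from compound 2 comes with no change in heavy-atom count. Nothing available gives a reason for this step.

Which part of 3-cyano-4-fluorophenyl carries the step stays open: the nitrile and the fluorine enter together, and a plain phenyl or a phenyl bearing an amine would separate them. Also open, going by these compounds, is how a carboxylic acid in place of the ethyl ester would read on this group.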